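This account rests on a few compounds, and the source may have more. Where it says the series, first, only, none or still open, it means among the compounds named here.

Of the compounds shown here, three that share one core have so far been tested in an ADME assay on Vero cells (Chlorocebus sabaeus) for cytotoxicity, read by MTT assay, with a stated time of 72 h; a higher number here means a weaker inhibitor, a lower number a stronger inhibitor. Compound 1, `O=C(NCc1ccco1)NNC(=O)c1cc([N+](=O)[O-])c[nH]1`, gives 443000 nM. Compound 2, `O=C(NNC(=O)c1cc([N+](=O)[O-])c[nH]1)Nc1ccc(Br)cc1`, gives 378000 nM. Compound 3, `COc1ccc(NC(=O)NNC(=O)c2cc([N+](=O)[O-])c[nH]2)cc1`, gives 401000 nM. The step of a 1.2-fold lower number from compound 1 to compound 2 (0.07 log units; within the scatter) and the step of a 1.1-fold higher number from compound 2 to compound 3 (0.03 log units; within the scatter) are both small, so although the number for compound 2 is the smallest of the three as written, its gaps to compound 1 and compound 3 are within the scatter and the three compounds cannot be told apart on these numbers.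

Compound 4, `O=C(NNC(=O)c1cc([N+](=O)[O-])c[nH]1)NC1CCCC1`, is the next to be measured. It differs from compound 2 in one place: cyclopentyl in place of 4-bromophenyl on an amide-type nitrogen. The step of a 1.2-fold lower number from compound 1 to compound 2 (0.07 log units; within the scatter) exchanged the group on the same amide-type nitrogen and stayed within the scatter, and the step of a 1.1-fold higher number from compound 2 to compound 3 (0.03 log units; within the scatter) changed a substituent on the aromatic ring and also stayed within the scatter. Neither involves cyclopentyl, so the data give no ground to expect a step beyond the scatter here. The expected change is a 1.1-fold higher number from compound 2 to compound 4 (0.02 log units; within the scatter). Compound 4 is estimated at 400000 nM in this assay, with a range from 200000 nM to 800000 nM.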

Compound 4, half-maximal inhibitory concentration: 231000 nM
Estimate against measurement, compound 4: 1.7-fold (0.24 log units) above; low and high end bracket the measured number.
By their numbers in this assay, from the lowest: compounds 4, 2, 3 and 1 (each within the scatter of the next).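

In this assay, within the data shown here, the amide-type nitrogen now carries a non-aromatic ring for the first time, and putting cyclopentyl in place of 4-bromophenyl gives a 1.6-fold lower number from compound 2 to compound 4 (0.21 log units; within the scatter) while the exchange for (furan-2-yl)methyl gives a 1.9-fold lower number from compound 1 to compound 4 (0.28 log units; within the scatter) and both steps stay within the scatter. The earlier change at this nitrogen swapped one group holding an aromatic ring for another, so only now is it seen that compound 4, with a five-membered carbon ring that is not aromatic, cannot be told apart from compound 1 or compound 2 on these numbers. Nothing measured here offers an explanation for the size of either step.

What remains open is whether any group on this nitrogen can move the number beyond the scatter at all, since every exchange shown so far has stayed within it. An amine, a carboxylic acid or a longer carbon chain in the same place would test this, as would a smaller group such as methyl, which would show how little this nitrogen needs to carry.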